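A few compounds are considered here, and "the series" means these few. Any claim that something is new, unique, unknown or untested is made for them only; others in the source may bear on it.

Measured compounds:
Compound 1 `C=C1C[C@]23C[C@@]1(O)CC[C@H]2c1ccc(OS(=O)(=O)c2ccc(C)cc2)c(C)c1[C@@H]3Cn1cc(-c2ccc(Br)cc2)nn1` in a functional assay on HL-60 cells (Homo sapiens) for cytotoxicity, read by MTT assay, with a stated time of 4 days (on this read-out lower numbers stand for stronger inhibition and higher numbers for weaker inhibition), gives > 20000 nM, a limit of the assay.
Compound 2 `C=C1C[C@]23C[C@@]1(O)CC[C@H]2c1ccc(OS(=O)(=O)c2ccc(C)cc2)c(C)c1[C@@H]3Cn1cc(-c2ccccc2)nn1` gives > 20000 nM, also a limit.
Compound 3 `C=C1C(=O)[C@]23C[C@@]1(O)CC[C@H]2c1ccc(O)c(C)c1[C@@H]3Cn1cc(-c2ccc(C(F)(F)F)cc2)nn1` gives 720 nM.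

For the measured compounds named here, compound 3 is the only compound with a number; the other two values are limits, as the limit of > 20000 nM in this assay, at which 2 of the 3 values shown sit, records. Going by the values given here, the one step between measured compounds, a step that the two limits leave unreadable from compound 1 to compound 2, has both ends at a limit and so cannot be read. Compound 4 `C=C1C(=O)[C@]23C[C@@]1(O)CC[C@H]2c1ccc(O)c(C)c1[C@@H]3Cn1cc(-c2ccc(Cl)cc2)nn1` differs from compound 3 by chloro in place of trifluoromethyl on an aromatic carbon. Among the compounds with values here, no measured step touches this kind of change, so nothing here sets its size. The expected step of a 1.4-fold higher number from compound 3 to compound 4 (0.14 log units; within the scatter) is therefore taken as small, within the usual scatter, in no firm direction. Compound 4 is estimated at 1000 nM, with a range from 400 nM to 2500 nM.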

Compound 4, half-maximal inhibitory concentration: 690 nM
For compound 4 the middle estimate is 1.4-fold (0.16 log units) above the measured one; the measured number falls inside the stated range.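

Putting chloro in place of trifluoromethyl on the six-membered aromatic ring gives, in this assay, a 1.0-fold lower number from compound 3 to compound 4 (0.02 log units; within the scatter), so on this core the two groups read alike. For the compounds shown here, this is the first step at this place that can be read, since the values of compound 1 and compound 2 are both limits and their step cannot be read. Nothing shown gives a reason why chloro and trifluoromethyl read alike. Still open, going by these compounds, is whether an amine, a carboxylic acid or a longer chain at this place would also leave the number within the scatter.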